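From Acid to Allyl Amide on a Shared Core

A few compounds are considered here, and "the series" means these few. Any claim that something is new, unique, unknown or untested is made for them only; others in the source may bear on it.

Within the data shown here, in a functional assay on MCF7 cells (Homo sapiens) for inhibition, read by radiometric assay and XTT assay (on this read-out lower numbers stand for stronger inhibition and higher numbers for weaker inhibition), compound 1 (`CCCCCCCC[C@@]1(C)SC(=O)C=C1OCC(=O)OCC`) gives 35.3 ug/mL and compound 2 (`CCCCCCCC[C@@]1(C)SC(=O)C=C1OCC(=O)O`) gives 50.3 ug/mL, so compound 2 sits within the usual scatter of its only measured neighbour. Compound 3 (`C=CCNC(=O)COC1=CC(=O)S[C@]1(C)CCCCCCCC`) carries allylamino in place of hydroxy on a carbonyl carbon. Among the measured compounds shown here, the only measured step is a 1.4-fold higher number from compound 1 to compound 2 (0.15 log units; within the scatter), and it is a different change, so it offers limited guidance. On that evidence, no step beyond the scatter is expected in this assay. The expected step is a 1.1-fold lower number from compound 2 to compound 3 (0.05 log units; within the scatter). For compound 3 the estimated value is 45 ug/mL, with an expected range of 18 ug/mL to 100 ug/mL.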

Compound 3, half-maximal inhibitory concentration: 12.1 ug/mL
The estimate for compound 3 lay 3.7-fold (0.57 log units) above the measured number; measured number outside the range, below it.
By their numbers in this assay, from the lowest: compound 3; then compounds 1 and 2 (each within the scatter of the next).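

In this assay allylamino in place of hydroxy on the carbonyl carbon gives a 4.2-fold lower number from compound 2 to compound 3 (0.62 log units; beyond the scatter) and allylamino in place of ethoxy gives a 2.9-fold lower number from compound 1 to compound 3 (0.46 log units; beyond the scatter). Compound 1 and compound 2 lie within the scatter of each other, so this position showed a step beyond the scatter only with the allylamino group of compound 3. No measurement shown here accounts for that step. The compounds shown leave open whether the double bond of the allyl group matters, which propylamino on the same carbonyl carbon would test, and how a ring-bearing benzylamino group would compare.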